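Cytotoxicity of three measured amides and one untested analogue

The source may report more compounds than this note shows. Statements on the series, on what has been measured and on what is new or still open speak of the compounds shown alone.

Compound 1 `CC(C)N(Cc1cccc(OCCCCCC(=O)O)c1)C(=O)c1ccc(-c2ccco2)cc1`: > 26000 nM
Compound 2 `CC(C)Oc1cccc(-c2ccc(C(=O)N(Cc3cccc(OCCCCCC(=O)O)c3)C(C)C)cc2)c1`: > 26000 nM
Compound 3 `CCOC(=O)CCCCCOc1cccc(CN(C(=O)c2ccc(-c3cccc(OC(C)C)c3)cc2)C(C)C)c1`: > 26000 nM

These three compounds were tested in an ADME assay on HEK293 cells (Homo sapiens) for cytotoxicity, read by CellTiter-Glo and resazurin assay, with a stated time of 72 h; a higher number here means that more compound is needed for the effect, a lower number that less compound is needed. For compound 1 the reported value is a limit of the assay and not a number. For compound 2 the reported value is likewise a limit. For compound 3 the reported value is also a limit. All three sit at the limit of > 26000 nM in this assay, at which 3 of the 3 values shown sit.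

From compound 2 to compound 1 the structural change is furan-2-yl in place of 3-isopropoxyphenyl on an aromatic carbon, and the step in this assay is a step that the two limits leave unreadable from compound 2 to compound 1. From compound 2 to compound 3 the change is ethyl in place of hydrogen on an oxygen next to a carbonyl group, which is how the core of compound 3 differs from that of compound 2, and the step here is a step that the two limits leave unreadable from compound 2 to compound 3.

Compound 4 `CCOC(=O)CCCCCOc1cccc(CN(C(=O)c2ccc(-c3ccco3)cc2)C(C)C)c1` has not yet been measured in this assay. It differs from compound 3 by furan-2-yl in place of 3-isopropoxyphenyl on an aromatic carbon, the same change as that from compound 2 to compound 1, made at the same place. Since that earlier change left the value at a limit, and since compound 3 itself sits at the limit of > 26000 nM in this assay, at which 3 of the 3 values shown sit, the step from compound 3 to compound 4 is expected to be a step that the limit leaves unreadable from compound 3 to compound 4. Compound 4 is therefore estimated to give 30000 nM in this assay, most likely again reported only as a limit, with a range from 15000 nM to 80000 nM.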

Compound 4, half-maximal effective concentration: > 26000 nM
Compound 4: no number, only a limit (the forecaster's own chance of this, stated with the estimate: 85%); the middle value is on the limit's open side.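

Compound 4 gives a limit and not a number, as do compound 1, compound 2 and compound 3, so neither new step, from compound 3 or from compound 1 to compound 4, can be read: the limit of > 26000 nM in this assay, at which 4 of the 4 values shown sit.

The compounds shown leave open where any of them would reach its half-maximal effect in this assay, and whether either furan-2-yl in place of 3-isopropoxyphenyl or ethyl in place of hydrogen shifts that concentration at all.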